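This account rests on a few compounds, and the source may have more. Where it says the series, first, only, none or still open, it means among the compounds named here.

Of the compounds shown here, three have so far been tested in an ADME assay on HaCaT cells (Homo sapiens) for antiproliferative activity, read by MTT assay, with a stated time of 48 h; a lower number here means a stronger inhibitor, a higher number a weaker inhibitor. Compound 1 `O=C(/C=C\Nc1ccc(C(F)(F)F)cc1)c1cn(-c2ccccc2)nc1-c1ccccc1` carries a trifluoromethyl group on the aniline and an unsubstituted phenyl on the shared core. Compound 1 reaches only a limit of the assay, > 50000 nM, which is the limit described in the limit of > 50000 nM in this assay, at which 1 of the 3 values shown sits. Compound 2 `O=C(/C=C\Nc1ccc(Cl)cc1)c1cn(-c2ccccc2)nc1-c1ccc(F)cc1` gives 21300 nM. Compound 3 `COc1cc(N/C=C\C(=O)c2cn(-c3ccccc3)nc2-c2ccc(Cl)cc2)cc(OC)c1OC`, with its trimethoxy aniline and a 4-chlorophenyl on the core, gives 46600 nM, the highest of the two numbers recorded; its nearest neighbour is compound 2, and that gap lies beyond the scatter.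

Compound 4 `COc1ccc(-c2nn(-c3ccccc3)cc2C(=O)/C=C\Nc2cc(OC)c(OC)c(OC)c2)cc1` differs from compound 3 in one place: methoxy in place of chloro on an aromatic carbon. Among the compounds with values here, no pair of measured compounds shows this same change, so its size cannot be read from the data. Since compound 3 already stands at 46600 nM, near the edge of the assay, the step from compound 3 to compound 4 is expected to be modest and, if anything, towards a higher number, a 1.2-fold lower number from compound 3 to compound 4 (0.07 log units; within the scatter). Compound 4 is therefore estimated at 40000 nM, expected to lie between 15000 nM and 120000 nM.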

Compound 4, half-maximal inhibitory concentration: > 50000 nM
Compound 4: no number, only a limit (the forecaster's own chance of this, stated with the estimate: 40%); middle value at least 1.2-fold (0.09 log units) from the limit.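

In this assay, the change from 4-chlorophenyl to 4-methoxyphenyl gives the series its first step between compounds that differ in one place, and it reads an at least 1.0-fold higher number from compound 3 to compound 4 (0.03 log units; that floor lies within the scatter). Compound 4 gives only a limit of the assay, > 50000 nM, and not a number. The step therefore shows no gain in potency from this change at this position, but its true size cannot be read because only its floor is fixed by the assay limit: the limit of > 50000 nM in this assay, at which 2 of the 4 values shown sit.

The compounds shown leave open whether a different group at this position, such as an amine or a carboxylic acid, would give a number clearly lower than that of compound 3. They also leave open whether the same change would give a readable step with the aniline of compound 2.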